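Fluoro to chloro swap on the core of compound 1

This account rests on a few compounds, and the source may have more. Where it says the series, first, only, none or still open, it means among the compounds named here.

Measured so far:
compound 1 `NS(=O)(=O)Cc1noc2ccc(F)cc12` gives 15 mg/kg
compound 2 `CCNS(=O)(=O)Cc1noc2ccc(F)cc12` gives 32 mg/kg

In a functional assay on the whole organism (strain STD-dd) with Mus musculus as the target, in the maximal electroshock model, with a stated time of 2 h (a lower number here means that less compound is needed, a higher number that more compound is needed for the effect), compound 1 stands at the lowest of the two numbers available; its nearest neighbour is compound 2, with a 2.1-fold higher number from compound 1 to compound 2 (0.33 log units; beyond the scatter) on going from the parent to the ethylated sulfonamide. Compound 3 `NS(=O)(=O)Cc1noc2ccc(Cl)cc12` is not yet measured. It differs from compound 1 only by chloro in place of fluoro on an aromatic carbon. Among the compounds with values here, no measured step touches the aromatic halogen; the one step in hand alters the sulfonamide nitrogen and was modest, so it gives no direct guide to the halogen swap and the outcome is open. Absent any evidence of a shift, no step beyond the scatter is expected for compound 3 in this assay. The estimate for compound 3 is 15 mg/kg, with a likely range from 7 mg/kg to 35 mg/kg. This estimate corresponds to an expected no change at the digits printed from compound 1 to compound 3 (within the scatter).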

Compound 3, dose for half-maximal effect: 14 mg/kg
The estimate for compound 3 lay 1.1-fold (0.03 log units) above the measured number; measured number inside the range.
By their numbers in this assay, from the lowest: compounds 3 and 1 (each within the scatter of the next); then compound 2.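

In this assay, within the data shown here, this aromatic position takes chloro in place of fluoro with no step that stands out from the scatter (a 1.1-fold lower number from compound 1 to compound 3 (0.03 log units; within the scatter)). The one earlier step, at the sulfonamide nitrogen (a 2.1-fold higher number from compound 1 to compound 2 (0.33 log units; beyond the scatter)), lies beyond the scatter, so among the compounds shown, that nitrogen is the only place where a step beyond the scatter appears, and this halogen swap leaves the number where it was. No measurement at hand bears on why the two halogens read alike.

The compounds shown cover only these two halogens at this position, so it stays open whether bromo, methoxy or plain hydrogen there would hold the number in this assay. Also open, on these data alone, is whether ethyl on the sulfonamide nitrogen gives a similar step on the chloro core, and how a carboxylic acid in place of the sulfonamide would read.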